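A few compounds are considered here, and "the series" means these few. Any claim that something is new, unique, unknown or untested is made for them only; others in the source may bear on it.

Working notes on the series. In a functional assay on NCI-H1975 cells (Homo sapiens) for cytotoxicity, read by CCK-8 assay, with a stated time of 72 h (on this read-out lower numbers stand for stronger inhibition and higher numbers for weaker inhibition), compound 1 `COc1ccccc1/C=c1\c(=O)[nH]/c(=C/c2ccccc2Cl)c(=O)n1C` gives 200 nM, compound 2 `C=CCn1c(=O)/c(=C\c2ccccc2OC)[nH]c(=O)/c1=C\c1ccccc1OC` gives 21500 nM, and compound 3 `C=CCn1c(=O)/c(=C\c2ccccc2F)[nH]c(=O)/c1=C\c1ccccc1OC` gives 25100 nM. Compound 3 stands highest of the three numbers, with compound 2 nearest and compound 1 far lower. Compound 4 `C=CCn1c(=O)/c(=C\c2ccccc2Cl)[nH]c(=O)/c1=C\c1ccccc1OC` differs from compound 3 by chloro in place of fluoro on an aromatic carbon. Among the compounds with values here, the one step that bears on this, a 1.2-fold higher number from compound 2 to compound 3 (0.07 log units; within the scatter), was within the scatter, so a change at this aromatic carbon has so far left the number about where it was. Compound 1 carries the same chloro, but differs from compound 4 elsewhere too, and only its value can be noted. For compound 4, the expected step is a 1.3-fold lower number from compound 3 to compound 4 (0.10 log units; within the scatter), none beyond the scatter. Compound 4 is therefore estimated at 20000 nM, within 8000 nM to 50000 nM.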

Compound 4, half-maximal inhibitory concentration: 9200 nM
Estimate against measurement, compound 4: 2.2-fold (0.34 log units) above; the measured number falls inside the stated range.
By their numbers in this assay, from the lowest: compound 1; then compound 4; then compounds 2 and 3 (each within the scatter of the next).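

In this assay this aromatic carbon does respond to the group it carries: chloro in place of fluoro gives a 2.7-fold lower number from compound 3 to compound 4 (0.44 log units; beyond the scatter) and chloro in place of methoxy gives a 2.3-fold lower number from compound 2 to compound 4 (0.37 log units; beyond the scatter), both modest, whereas a 1.2-fold higher number from compound 2 to compound 3 (0.07 log units; within the scatter) stayed within the scatter. Vinyl in place of hydrogen on the chain carbon bound to the aromatic nitrogen gives the far larger a 46-fold higher number from compound 1 to compound 4 (1.66 log units; beyond the scatter), so the chloro compound remains much weaker with that chain. No measurement at hand accounts for either change. Open, going by these compounds, is how an amine or a carboxylic acid would read at this aromatic carbon, and how a longer chain would read on the aromatic nitrogen.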